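The source may hold more compounds than are shown below. What is called first, only, known or untested is meant among the compounds shown, and "the series" means these compounds.

Working notes on the sulfonamide series.

Of the compounds shown here, three have been measured in an ADME assay (liver) for metabolic stability, with Liver microsome (Homo sapiens) as the target, read by LC-MS, using microsomes and NADPH, with a stated time of 5 min, at 37 degrees C; a lower number here means slower removal, a higher number faster removal of the compound. Compound 1 `CCn1c([C@@H](C)NS(=O)(=O)c2ccc(Cl)cc2)nc2ccc(OC)cc21` returns only a limit of the assay, > 100 mL.min-1.g-1. Compound 3 `CCn1c([C@@H](C)NS(=O)(=O)c2ccc(NC(C)=O)c(C)c2)nc2ccc(C(F)(F)F)cc21` likewise returns a limit of the assay, > 100 mL.min-1.g-1. Going by the values given here, compound 2 `CCn1c([C@@H](C)NS(=O)(=O)c2ccc(C#N)cc2)nc2ccc(C(F)(F)F)cc21` is the only member of the three to give a number, and in this assay compound 2 gives 34 mL.min-1.g-1. Among the compounds with values here, compound 2 therefore stands alone: the other two values sit at the limit of > 100 mL.min-1.g-1 in this assay, at which 2 of the 3 values shown sit, so no step between two measured compounds can be stated, and nothing in the measured set shows how a change on the sulfonyl sulfur moves this assay.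

The step to be followed runs from compound 2 to compound 4 `CCn1c([C@@H](C)NS(=O)(=O)c2cnc(C)n2C)nc2ccc(C(F)(F)F)cc21`. The change is 1,2-dimethyl-1H-imidazol-5-yl in place of 4-cyanophenyl on a sulfonyl sulfur. Within the data shown here, no measured step of this kind exists, so the expectation rests on compound 2 alone. Compound 4 is expected to stay close to compound 2, with a step from compound 2 to compound 4 of a 1.4-fold lower number from compound 2 to compound 4 (0.13 log units; within the scatter), which is expected to be within the usual scatter or a little slower removal. For compound 4 in this assay the estimate is 25 mL.min-1.g-1, with a range from 10 mL.min-1.g-1 to 70 mL.min-1.g-1.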

Compound 4, intrinsic clearance in microsomes: 58 mL.min-1.g-1
Beside the measured number, compound 4's estimate is 2.3-fold (0.37 log units) below it, and the stated range covers the measured number.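

Going by these compounds alone, with compound 4, a step at the sulfonyl sulfur can be read for the first time in this assay, and it is a 1.7-fold higher number from compound 2 to compound 4 (0.23 log units; within the scatter). So 1,2-dimethyl-1H-imidazol-5-yl and 4-cyanophenyl on a sulfonyl sulfur, a five-membered aromatic ring with 2 hetero atoms and a six-membered aromatic ring of carbon only, cannot be told apart in this read-out, and with either group the shared remainder of the molecule gives a number rather than a limit of the assay. Steps from compound 1 or compound 3 to the other compounds cannot be read, because the values of those two compounds are limits and not numbers: the limit of > 100 mL.min-1.g-1 in this assay, at which 2 of the 4 values shown sit.

From the compounds shown here alone, this single pair gives no trend for the sulfonyl sulfur, and it remains unknown whether any group there would give a step beyond the scatter in this assay. Going by these compounds, how a saturated chain carrying an amine, or a phenyl ring carrying a carboxylic acid, would read on the same sulfonyl sulfur stays open.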